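The source may report more compounds than this note shows. Statements on the series, on what has been measured and on what is new or still open speak of the compounds shown alone.

Measured compounds and values:

- Compound 1 `COc1ccc(-c2cc(/C=C/C(=O)c3ccc(N)cc3)[nH]n2)cc1`: 34900 nM
- Compound 2 `COc1ccc(C(=O)/C=C/c2cc(-c3cc(OC)c(OC)c(OC)c3)n[nH]2)cc1OC`: 6400 nM
- Compound 3 `COc1cc(-c2cc(/C=C/C(=O)c3ccc(F)c(F)c3)[nH]n2)cc(OC)c1OC`: > 100000 nM

Notes on the series. In a functional assay on HCT-15 cells (Homo sapiens) for inhibition, read by sulforhodamine B assay, with a stated time of 48 h (on this read-out lower numbers stand for higher toxicity in this test and higher numbers for lower toxicity in this test), compound 1 gives 34900 nM, the highest of the two numbers recorded, with compound 2 the nearest at a value that is lower by a gap beyond the scatter. For compound 3 the assay reports only a limit, > 100000 nM, and no number. For the measured compounds named here, the one measured step on a single change, an at least 15-fold higher number from compound 2 to compound 3 (1.19 log units; beyond the scatter), concerns the aryl ring on the carbonyl carbon and is large; it is bounded by the limit of > 100000 nM in this assay, at which 1 of the 3 values shown sits.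

Compound 4 `COc1ccc(-c2cc(/C=C/C(=O)c3ccc(N)cc3)[nH]n2)cc1OC` differs from compound 1 in a single place: methoxy in place of hydrogen on an aromatic carbon. Going by the values given here, no measured step concerns this position, so the change is uncharted. Among the compounds with values here, compound 1 and compound 2 differ in two places at once, and their values show only that the compound carrying more methoxy groups, compound 2, returns the lower number. On that slender footing a modest shift towards a lower number is expected for compound 4, not safely beyond the scatter, as a 1.7-fold lower number from compound 1 to compound 4 (0.24 log units; within the scatter). Compound 4 is therefore estimated in this assay at 20000 nM, with a range from 7000 nM to 60000 nM.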

Compound 4, concentration lethal to 50% of the cells: 33000 nM
Estimate against measurement, compound 4: 1.7-fold (0.22 log units) below, within the range that was stated.
By their numbers in this assay, from the lowest: compound 2; then compounds 4 and 1 (each within the scatter of the next). At a limit, above all of these: compound 3.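

In this assay the added methoxy, on an aromatic carbon ortho to a methoxy group and meta to a large group, leaves the read-out flat: a 1.1-fold lower number from compound 1 to compound 4 (0.02 log units; within the scatter). For the compounds shown here, this is the first measured step at this position, which the earlier compounds left uncharted, and it shows that, with the rest of compound 1 unchanged, the position takes a methoxy group without a shift that can be told from the scatter. Nothing measured here offers a cause for so small a step.

Going by these compounds, whether the position stays as flat for other groups remains open: a hydroxy group, a chlorine atom or a longer chain such as ethoxy could read differently, and one step with one group does not speak for them. Also open, on these data alone, is whether the step holds when the aryl ring on the carbonyl carbon is changed, as it is in compound 3, whose > 100000 nM is a limit of the assay and not a number.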